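This account rests on a few compounds, and the source may have more. Where it says the series, first, only, none or still open, it means among the compounds named here.

Working notes on the series. Two compounds have been run in a functional assay on K562 cells (Homo sapiens) for cytotoxicity, read by trypan blue exclusion, with a stated time of 96 h (a higher number here means a weaker inhibitor, a lower number a stronger inhibitor), so far: compound 1 `COc1cc(OC)c(/C=C/SCc2ccc(OC)c([N+](=O)[O-])c2)c(OC)c1` gives 5000 nM, and compound 2 `COC(=O)C(F)(F)Nc1cc(CS(=O)(=O)/C=C/c2c(OC)cc(OC)cc2OC)ccc1OC` gives 250 nM. Compound 2 holds the lowest of the two numbers; its nearest neighbour on the scale is compound 1, and the gap between them lies beyond the scatter. The two structures differ in more than one place, so only their two values are set side by side.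

Compound 3 `COc1cc(OC)c(/C=C/S(=O)(=O)Cc2ccc(OC)c(NC(C(=O)O)c3ccc(Br)cc3)c2)c(OC)c1` is still to be measured in this assay. It differs from compound 2 at a single place: (4-bromophenyl)(carboxy)methyl in place of difluoro(methoxycarbonyl)methyl on a nitrogen on an aromatic ring. Among the compounds with values here, no single-point step between measured compounds exists in this set, so there is no measured precedent for the change. The step of a 3.2-fold higher number from compound 2 to compound 3 (0.51 log units; beyond the scatter) is expected to run toward a higher number, of modest size, though a result within the scatter would not surprise. Compound 3 is estimated at 800 nM, with a range from 150 nM to 4000 nM.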

Compound 3, half-maximal inhibitory concentration: 200 nM
Beside the measured number, compound 3's estimate is 4.0-fold (0.60 log units) above it; low and high end bracket the measured number.
By their numbers in this assay, from the lowest: compounds 3 and 2 (each within the scatter of the next); then compound 1.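

Within the data shown here, this is the first single-place step: in this assay, (4-bromophenyl)(carboxy)methyl in place of difluoro(methoxycarbonyl)methyl on a nitrogen on an aromatic ring gives a 1.3-fold lower number from compound 2 to compound 3 (0.10 log units; within the scatter). The entering group brings a six-membered aromatic ring of carbon only and a hydrogen-bond donor that the leaving group lacks, and even so this read-out does not separate compound 2 from compound 3. No measured data bear on why the two groups read alike.

The step changes several features at once, so the compounds shown do not tell which part of either group matters at this nitrogen. On these data alone, how a plain amine, or a carboxymethyl group without the 4-bromophenyl ring, would read on the same nitrogen stays open.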